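The source may hold more compounds than are shown below. What is called first, only, known or untested is meant among the compounds shown, and "the series" means these compounds.

Measured compounds:
compound 1 `CCc1cccc2cc(C(=O)O)cnc12` – > 50 mg/kg
compound 2 `Cc1ccc2cc(C(=O)O)cnc2c1C` – 25 mg/kg
compound 3 `Cc1cccc2cc(C(=O)O)cnc12` – > 50 mg/kg

In a functional assay on the whole organism (strain Sprague-Dawley) for inhibition, with Rattus norvegicus as the target (a lower number here means that less compound is needed, a higher number that more compound is needed for the effect), compound 3 reaches only a limit of the assay, not a number. Compound 2 gives a number, and the step of an at least 2.0-fold higher number from compound 2 to compound 3 (0.30 log units; that floor lies within the scatter) follows from a hydrogen in place of a methyl on an aromatic carbon. Compound 1 likewise ends at a limit, so the step that the two limits leave unreadable from compound 1 to compound 3 cannot be sized. Two of the three values sit at the limit of > 50 mg/kg in this assay, at which 2 of the 3 values shown sit. Compound 4 `O=C(O)c1cnc2c(C(F)(F)F)cccc2c1` differs from compound 3 by trifluoromethyl in place of methyl on an aromatic carbon. Among the measured compounds shown here, no measured step exchanges a methyl for a trifluoromethyl, so neither step bears directly on this change. Compound 4 is therefore expected to stay near the limit of compound 3, a step of a number no higher from compound 3 to compound 4 (the limit leaves the size open). The estimate for compound 4 is 50 mg/kg, between 25 mg/kg and 100 mg/kg.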

Compound 4, minimum effective dose: 50 mg/kg
For compound 4 middle estimate and measured number coincide at the digits printed; the range from low to high includes it.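

Among compound 1, compound 3 and compound 4, which differ only in the group on this aromatic carbon, compound 4 alone gives a number in this assay: 50 mg/kg. Trifluoromethyl in place of methyl here gives a number no higher from compound 3 to compound 4 (the limit leaves the size open), and trifluoromethyl in place of ethyl here gives a number no higher from compound 1 to compound 4 (the limit leaves the size open). The size of either step cannot be read, because compound 1 and compound 3 end at a limit: the limit of > 50 mg/kg in this assay, at which 2 of the 4 values shown sit.

The compounds shown leave open how far the methyl and ethyl compounds lie from compound 4. They also leave open how a chlorine or a methoxy group on this carbon would read.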